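Taking the chloro off compound 2

The compounds below may be only part of what the source reports. "The series", "measured", "known", "first", "only" and "open" are said of these compounds alone.

Measured in a physicochemical assay for lipophilicity; on this read-out lower numbers stand for lower lipophilicity and higher numbers for higher lipophilicity:
compound 1 `CCOC[C@H](Oc1ncnc2c1cnn2-c1ncccc1Cl)C(=O)Nc1ccccn1`: 2.1
compound 2 `CC(C)OC[C@H](Oc1ncnc2c1cnn2-c1ncccc1Cl)C(=O)Nc1ccc(Cl)cn1`: 3.5
compound 3 `CCOC[C@H](Oc1ncnc2c1cnn2-c1ncccc1Cl)C(=O)Nc1ccc(Cl)cn1`: 3

Of these three, compound 2 stands highest, at 3.5. Compound 4 `CC(C)OC[C@H](Oc1ncnc2c1cnn2-c1ncccc1Cl)C(=O)Nc1ccccn1` has not yet been measured. It differs from compound 2 in one place: hydrogen in place of chloro on an aromatic carbon. This is hydrogen in place of chloro on an aromatic carbon, so 5-chloropyridin-2-yl becomes pyridin-2-yl.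

The closest guide is the same change seen in the opposite direction: a number 0.90 log units higher from compound 1 to compound 3 (beyond the scatter). Removing the chloro from compound 2 should therefore bring a fall of similar size. The other measured step, a number 0.50 log units lower from compound 2 to compound 3 (beyond the scatter), gives a cross-check, since compound 4 should then sit above compound 1 by that same margin. Among the compounds with values here, both routes lead to the same place, although only one pair shows the chloro change directly. In this assay, the expected change is a number 0.90 log units lower from compound 2 to compound 4 (beyond the scatter), a fall beyond the scatter. For compound 4 the estimate is 2.6, with an expected range from 2.3 to 2.9.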

Compound 4, distribution coefficient: 2.5
The estimate for compound 4 lay 0.10 log units above the measured number; measured number inside the range.
By their numbers in this assay, from the lowest: compound 1; then compound 4; then compound 3; then compound 2.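

In this assay, removing the chloro from the 5-chloropyridin-2-yl group gives a number 1.00 log units lower from compound 2 to compound 4 (beyond the scatter) and so repeats, on a second side chain, a change of similar size to the opposite step a number 0.90 log units higher from compound 1 to compound 3 (beyond the scatter) seen earlier. The methyl change also repeats, with a number 0.40 log units higher from compound 1 to compound 4 (beyond the scatter) on the pyridin-2-yl compounds set against a number 0.50 log units lower from compound 2 to compound 3 (beyond the scatter) on the chloro compounds, so across these four compounds each change keeps nearly the same size whichever form the other place takes, and none of the four goes against this. Nothing available here explains the size of either step.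

Still open, as far as these compounds go, is how a nitrile or an amine on the same aromatic carbon would compare with chloro and hydrogen. Also open, from the compounds shown here alone, is whether a longer chain on the ether oxygen would continue the rise seen with the added methyl.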